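The source may report more compounds than this note shows. Statements on the series, on what has been measured and on what is new or still open speak of the compounds shown alone.

Measured compounds:
- Compound 1, `CCCCCCNc1nc(-c2ccccc2)nc2c1nnn2Cc1ccccc1C(F)(F)F`: "not determined" (no result reported) in an assay on Cerebral cortex for displacement of a labelled ligand from adenosine receptor A1 (Bos taurus); on this read-out higher numbers stand for weaker inhibition and lower numbers for stronger inhibition
- Compound 2, `Fc1ccccc1Cn1nnc2c(NC3CCCCC3)nc(-c3ccccc3)nc21`: 1.15 nM

Among the measured compounds shown here, compound 2 is the only compound of this set with a number in this assay; compound 1 carries no result there, so nothing can be said about how the two compare. The value of compound 2 in this assay is therefore the sole point of reference for what follows.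

Compound 3, `FC(F)(F)c1ccccc1Cn1nnc2c(NC3CCCCC3)nc(-c3ccccc3)nc21`, differs from compound 2 in one place: trifluoromethyl in place of fluoro on an aromatic carbon. For the measured compounds named here, no measured pair in this set shows the effect of that change, so any expectation for compound 3 rests on the value of compound 2 alone. The change is expected to cost little, with a step of a 2.2-fold higher number from compound 2 to compound 3 (0.34 log units; beyond the scatter) that may well stay within the usual scatter of this assay. On that basis compound 3 is expected to give about 2.5 nM in this assay, within a range from 0.6 nM to 12 nM.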

Compound 3, inhibition constant: 6.8 nM
Beside the measured number, compound 3's estimate is 2.7-fold (0.43 log units) below it; measured number inside the range.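

In this assay, among the compounds shown here, replacing 2-fluorobenzyl with 2-(trifluoromethyl)benzyl gives a 5.9-fold higher number from compound 2 to compound 3 (0.77 log units; beyond the scatter) and provides the first measured step at this place on the six-membered aromatic ring, ortho to a large group. The position is therefore not indifferent to exchanging fluoro, with 1 heavy atom, for trifluoromethyl, with 4 heavy atoms, although the step is modest and compound 3 still gives 6.8 nM in this read-out. No measured information is available to explain the step.

With only this single pair, the compounds shown cannot tell whether the higher number follows from the number of heavy atoms in the group or from some other difference between fluoro and trifluoromethyl. They also leave open how a plain hydrogen, a chloro or methyl group, or a methoxy or nitrile group at this same place would compare with fluoro and trifluoromethyl, and whether the step would be the same on a different amine substituent of the shared core.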